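A few compounds are considered here, and "the series" means these few. Any claim that something is new, unique, unknown or untested is made for them only; others in the source may bear on it.

Of the compounds shown here, three built on one shared core have been tested in a functional assay on MCF7 cells (Homo sapiens) for antiproliferative activity, read by MTT assay, with a stated time of 96 h; on this read-out lower numbers stand for stronger inhibition and higher numbers for weaker inhibition. Compound 1 `O=C1NNC(=O)C2(CSC3=C2C(=O)c2ncccc2C3=O)N1` gives 1250 nM. Compound 2 `O=C1NC(=O)C2(CSC3=C2C(=O)c2ncccc2C3=O)N1` gives 120 nM. Compound 3 `O=C1C2=C(C(=O)c3ncccc31)C1(CS2)NC(=O)N(c2ccc(Cl)cc2)C1=O` gives 4 nM, the lowest of the three numbers; its nearest neighbour is compound 2, and the gap to compound 1 is wider still. The only single-point step among these, a 30-fold lower number from compound 2 to compound 3 (1.48 log units; beyond the scatter), concerns a different part of the molecule. Compound 4 `CC(C)(C)c1ccc(N2C(=O)NC3(CSC4=C3C(=O)c3ncccc3C4=O)C2=O)cc1` differs from compound 3 by tert-butyl in place of chloro on an aromatic carbon, placed on an aromatic carbon of a six-membered aromatic ring of carbon only, para to a large group. For the measured compounds named here, no measured step bears on this exchange, so no change beyond the scatter is expected, and the estimated step is a 1.5-fold higher number from compound 3 to compound 4 (0.18 log units; within the scatter). Compound 4 is therefore expected to give about 6 nM, between 1.5 nM and 25 nM.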

Compound 4, half-maximal inhibitory concentration: 130 nM
Estimate against measurement, compound 4: 22-fold (1.34 log units) below; the measured number lies above the stated range.
By their numbers in this assay, from the lowest: compound 3; then compounds 2 and 4 (each within the scatter of the next); then compound 1.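

The group on this aromatic carbon, para to a large group, matters a great deal: tert-butyl in place of chloro costs most of the gain in inhibition (a 33-fold higher number from compound 3 to compound 4 (1.51 log units; beyond the scatter)). Adding an aryl group on the ring nitrogen therefore does not help in itself, as 4-(tert-butyl)phenyl in place of hydrogen brings no real change (a 1.1-fold higher number from compound 2 to compound 4 (0.03 log units; within the scatter)). No evidence here explains why these two groups differ.

On these data alone, whether fluoro, methoxy or an amine at this place would behave like chloro or like tert-butyl remains open.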